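A few compounds are considered here, and "the series" means these few. Any claim that something is new, unique, unknown or untested is made for them only; others in the source may bear on it.

Compound 1 `CCC1(Cc2ccccc2)OS(=O)(=O)C=C1OCc1ccc(F)cc1` was tested in an ADME assay on HEL cells (Homo sapiens) for cytotoxicity, with a stated time of 3 days; a higher number here means that more compound is tolerated, a lower number that less compound is tolerated. In this assay compound 1 gives >= 50000 nM, which is a limit of the assay and not a number. On the numbers shown, compound 1 therefore stands only at a limit, and the two other measured compounds also stand at limits. Compound 2 `CCC1(Cc2ccccc2)OS(=O)(=O)C=C1OCc1ccc(OC)cc1` gives >= 200000 nM in this assay, again only a limit. Compound 3 `CCC1(Cc2ccccc2)OS(=O)(=O)C=C1OCc1ccc(Cl)c(Cl)c1` gives >= 20000 nM in this assay, once more a limit. The step from compound 1 to compound 2, methoxy in place of fluoro on an aromatic carbon, reads a step that the two limits leave unreadable from compound 1 to compound 2. The steps a step that the two limits leave unreadable from compound 1 to compound 3 and a step that the two limits leave unreadable from compound 2 to compound 3 are likewise not readable, because every value sits at a limit, (the limit of >= 20000 nM in this assay, at which 1 of the 3 values shown sits), the limit of >= 200000 nM in this assay, at which 1 of the 3 values shown sits, and (the limit of >= 50000 nM in this assay, at which 1 of the 3 values shown sits).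

Compound 4 `CCC1(Cc2ccccc2)OS(=O)(=O)C=C1OCc1ccc(C)cc1` differs from compound 1 in this way: methyl in place of fluoro on an aromatic carbon. The step from compound 1 to compound 2 bears most directly on it, as the same aromatic carbon is changed, but its size cannot be read. Among the compounds with values here, no measured step gives a direction, so compound 4 is expected to behave like compound 1 and to reach only a limit in this assay, an expected step of a number no higher from compound 1 to compound 4 (the limit leaves the size open). The estimate for compound 4 is 50000 nM, with a range from 20000 nM to 200000 nM.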

Compound 4, minimum cytotoxic concentration: >= 16000 nM
Compound 4: no number, only a limit (the forecaster's own chance of this, stated with the estimate: 85%); the middle value does not contradict the limit.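

No new step can be read: compound 4 stands only at a limit in this assay, as do compound 1, compound 2 and compound 3, so its comparisons with all three stay unreadable. The compounds shown leave open whether methyl, fluoro or methoxy on the aromatic carbon makes any difference to the concentration tolerated.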